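A few compounds are considered here, and "the series" means these few. Any claim that something is new, unique, unknown or untested is made for them only; others in the source may bear on it.

Of the compounds shown here, three that share one core have been measured in a functional assay on RAW264.7 cells (Mus musculus) for inhibition, read by Griess assay, with stated times of 2 h and 24 h; on this read-out lower numbers stand for stronger inhibition and higher numbers for weaker inhibition. Compound 1 `COc1ccc([C@@H]2CC(=O)c3c(O)cc(OCc4cn(Cc5cccc(C(F)(F)F)c5)nn4)cc3O2)cc1O` gives 19900 nM in this assay, the highest of the three numbers, though all three sit close together. Compound 2 `COc1ccc([C@@H]2CC(=O)c3c(O)cc(OCc4cn(Cc5cccc(C#N)c5)nn4)cc3O2)cc1O` gives 18000 nM, and compound 3 `COc1ccc([C@@H]2CC(=O)c3c(O)cc(OCc4cn(Cc5ccc(C(F)(F)F)cc5)nn4)cc3O2)cc1O` gives 17700 nM. Putting cyano in place of trifluoromethyl on an aromatic carbon gives a 1.1-fold lower number from compound 1 to compound 2 (0.04 log units; within the scatter); putting 4-(trifluoromethyl)phenyl in place of 3-(trifluoromethyl)phenyl on a saturated chain carbon bound to an aromatic nitrogen gives a 1.1-fold lower number from compound 1 to compound 3 (0.05 log units; within the scatter); and from compound 2 to compound 3 the step is a 1.0-fold lower number from compound 2 to compound 3 (0.01 log units; within the scatter). None of these steps exceeds the scatter.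

Compound 4 `COc1ccc([C@@H]2CC(=O)c3c(O)cc(OCc4cn(C5CCC5)nn4)cc3O2)cc1O` has not been measured. It differs from compound 1 in one place: cyclobutyl in place of 3-(trifluoromethyl)benzyl on an aromatic nitrogen. Among the measured compounds shown here, no measured step removes the aromatic ring from the group on the aromatic nitrogen; the measured steps only swap or move a substituent on that ring, and each of them left the number essentially unchanged. On that basis the step from compound 1 to compound 4 is expected to be a 1.0-fold higher number from compound 1 to compound 4 (0.00 log units; within the scatter), no step beyond the scatter, though a change this large carries more uncertainty than the measured ones. Compound 4 is therefore estimated at 20000 nM, with a range from 8000 nM to 50000 nM.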

Compound 4, half-maximal inhibitory concentration: 15300 nM
Beside the measured number, compound 4's estimate is 1.3-fold (0.12 log units) above it; the range from low to high includes it.
By their numbers in this assay, from the lowest: compounds 4, 3, 2 and 1 (each within the scatter of the next).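

In this assay, the group on the aromatic nitrogen can lose its six-membered aromatic ring altogether: 3-(trifluoromethyl)benzyl, with 11 heavy atoms, gives way to cyclobutyl, with 4 heavy atoms, and the result is a 1.3-fold lower number from compound 1 to compound 4 (0.11 log units; within the scatter). The other two benzyl compounds read the same way, giving a 1.2-fold lower number from compound 3 to compound 4 (0.06 log units; within the scatter) and a 1.2-fold lower number from compound 2 to compound 4 (0.07 log units; within the scatter), so this position now accepts the loss of the whole benzyl group and not only a swapped or moved substituent on its ring, and none of compound 1, compound 2, compound 3 or compound 4 goes against this. Nothing measured alongside these numbers explains why they stay so close together.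

On these data alone, all four compounds carry a ring of carbon only on that nitrogen, and their numbers all lie within the scatter of one another, so it remains open whether an amine, a carboxylic acid or a longer chain at this position would shift the number at all. As far as these compounds go, it also remains open whether any change elsewhere on the shared core, away from this nitrogen, would move the number beyond the scatter.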